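Growing the Amide Group: Liver-Cell Toxicity Stays Silent?

The compounds below may be only part of what the source reports. "The series", "measured", "known", "first", "only" and "open" are said of these compounds alone.

Compound 3 `CC(C(=O)N1CCOCC1)N1CCN(S(=O)(=O)c2ccc(C(C)(C)C)cc2)CC1` carries a morpholin-4-yl group on its carbonyl carbon. In an ADME assay on HepG2 cells (Homo sapiens) for inhibition, with a stated time of 48 h (on this read-out lower numbers stand for an effect already at smaller amounts and higher numbers for an effect only at larger amounts of compound), compound 3 gives > 40000 nM, which is a limit of the assay rather than a measured number. Its two measured relatives differ only in the group on that same carbonyl carbon. Compound 1 `CCN(CC)C(=O)C(C)N1CCN(S(=O)(=O)c2ccc(C(C)(C)C)cc2)CC1` bears a diethylamino group, and in this assay compound 1 gives > 40000 nM, again a limit. Compound 2 `CC(C(=O)N1CC2CC2C1)N1CCN(S(=O)(=O)c2ccc(C(C)(C)C)cc2)CC1` bears a bicyclic amine, and in this assay compound 2 gives > 40000 nM, also a limit. The three steps between them, a step that the two limits leave unreadable from compound 1 to compound 2, a step that the two limits leave unreadable from compound 1 to compound 3 and a step that the two limits leave unreadable from compound 2 to compound 3, therefore cannot be sized, because every value sits at the limit of > 40000 nM in this assay, at which 3 of the 3 values shown sit.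

The change now followed is 1,2,3,4-tetrahydroisoquinolin-2-yl in place of morpholin-4-yl on a carbonyl carbon, giving compound 4 `CC(C(=O)N1CCc2ccccc2C1)N1CCN(S(=O)(=O)c2ccc(C(C)(C)C)cc2)CC1`. The entering group brings a carbon-only aromatic ring and removes the single hydrogen-bond acceptor of the leaving group. Among the compounds with values here, none of the measured steps gives a readable size, so nothing in the data points to an effect appearing at smaller amounts. The step of a number no higher from compound 3 to compound 4 (the limit leaves the size open) is expected to be none beyond the scatter. Compound 4 is thus estimated at 40000 nM, with a range from 15000 nM to 100000 nM.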

Compound 4, half-maximal effective concentration: 29000 nM
Compound 4: the middle estimate sits 1.4-fold (0.14 log units) above what was measured; low and high end bracket the measured number.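

Within the data shown here, compound 4, with 1,2,3,4-tetrahydroisoquinolin-2-yl on the carbonyl carbon, is the first compound here to give a measured number rather than a limit in this assay, so a change at this position can bring the read-out within the range of the assay. The new comparisons are an at least 1.3-fold lower number from compound 3 to compound 4 (0.13 log units; that floor lies within the scatter), an at least 1.3-fold lower number from compound 2 to compound 4 (0.13 log units; that floor lies within the scatter) and an at least 1.3-fold lower number from compound 1 to compound 4 (0.13 log units; that floor lies within the scatter); each gives only a floor, so the real steps may be larger, but what is established does not go beyond the usual scatter. The steps among compound 1, compound 2 and compound 3 remain unreadable, and the three new steps have no upper size, because each of those compounds stops at a limit: the limit of > 40000 nM in this assay, at which 3 of the 4 values shown sit.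

The compounds shown do not separate the effect of the carbon-only aromatic ring from that of the greater number of heavy atoms in the entering group, a question that a piperidin-1-yl or benzylamino group on the carbonyl carbon could help answer. They also leave open whether a carboxylic acid or an amine on the aromatic ring would shift the number in this assay.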